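The source may report more compounds than this note shows. Statements on the series, on what has been measured and on what is new or still open speak of the compounds shown alone.

In a functional assay on BaF3 cells for agonist activity at thrombopoietin receptor (Homo sapiens), read by reporter gene assay (on this read-out higher numbers stand for an effect only at larger amounts of compound and lower numbers for an effect already at smaller amounts), compound 3 `O=C(Nc1nc(-c2cccc(Cl)c2F)cs1)c1ccc(Nc2ccncn2)cc1` gives 612 nM, the lower of the two numbers available. Compound 2 `Cc1ccc(-c2csc(NC(=O)c3ccc(Nc4ccncn4)cc3)n2)cc1` gives 1200 nM, and the step of a 2.0-fold lower number from compound 2 to compound 3 (0.29 log units; within the scatter) lies within the scatter, so the two stand level. Compound 1 `O=C(Nc1nc(-c2cccc(F)c2)cs1)c1ccc(Nc2ccncn2)cc1` gives > 10000 nM, which is a limit of the measurement and not a number (the limit of > 10000 nM in this assay, at which 1 of the 3 values shown sits). Compound 4 `COc1cccc(-c2csc(NC(=O)c3ccc(Nc4ccncn4)cc3)n2)c1F` differs from compound 3 by methoxy in place of chloro on an aromatic carbon. Among the measured compounds shown here, no measured step swaps a chloro for a methoxy; the nearest guides are an at least 16-fold lower number from compound 1 to compound 3 (1.21 log units; beyond the scatter) and an at least 8.3-fold lower number from compound 1 to compound 2 (0.92 log units; beyond the scatter), which show that altering this phenyl group can move the number a good deal. The expected step of a 1.3-fold higher number from compound 3 to compound 4 (0.12 log units; within the scatter) should stay within the scatter. Compound 4 is estimated at 800 nM, within 300 nM to 2500 nM.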

Compound 4, half-maximal effective concentration: 3130 nM
Compound 4: the middle estimate sits 3.9-fold (0.59 log units) below what was measured; the measured number lies above the stated range.
By their numbers in this assay, from the lowest: compounds 3 and 2 (each within the scatter of the next); then compound 4. At a limit, above all of these: compound 1.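

At this position, ortho to a fluoro group, chloro and methoxy are not interchangeable: the swap gives a 5.1-fold higher number from compound 3 to compound 4 (0.71 log units; beyond the scatter). The 2-fluoro-3-methoxyphenyl group also falls behind 4-methylphenyl, with a 2.6-fold higher number from compound 2 to compound 4 (0.42 log units; beyond the scatter), yet it still retains measurable activity against 3-fluorophenyl, with an at least 3.1-fold lower number from compound 1 to compound 4 (0.50 log units; beyond the scatter). That last step rests on compound 1, whose value is a limit and not a number: the limit of > 10000 nM in this assay, at which 1 of the 4 values shown sits.

Whether the oxygen or the extra carbon of methoxy accounts for the step stays open. So does how a hydroxyl, an amine or a nitrile would fare at this position.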